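The compounds below may be only part of what the source reports. "The series", "measured", "known", "first", "only" and "open" are said of these compounds alone.

Of the compounds shown here, three sharing one core have been tested in an assay on isolated protein for inhibition of thyroid hormone receptor beta (Homo sapiens), read by fluorescence, with a stated time of 30 min; on this read-out lower numbers stand for stronger inhibition and higher numbers for weaker inhibition. Compound 1 `CCCN(CC1CCOC1)C(=O)c1ccc2oc(NCc3cccc(Cl)c3)nc2c1` gives 214 nM. Compound 2 `COc1cc(C(=O)N2CCCC2(C)C)cc2nc(NCc3cccc(Cl)c3)oc12` gives 47 nM, and compound 3 `COc1cc(C(=O)N2CCC(O)C(C)C2)cc2nc(NCc3cc(Cl)ccc3O)oc12` gives 170 nM. Compound 2 thus stands with the lowest number of the three; compound 3 is the nearest and compound 1 the furthest, and both gaps lie beyond the scatter of repeated measurements.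

Compound 4 `COc1cc(C(=O)N2CC(C)C(O)CC2C2CC2)cc2nc(NCc3cccc(Cl)c3)oc12` has not yet been measured. It is built from compound 2 by one change: 2-cyclopropyl-4-hydroxy-5-methylpiperidin-1-yl in place of 2,2-dimethylpyrrolidin-1-yl on a carbonyl carbon. For the measured compounds named here, no pair of already measured compounds differs by exactly this change, so the size of the step has to be judged from the structures alone. Compound 3 also carries a hydroxy-bearing piperidine on its carbonyl carbon, but it differs from compound 2 in a second place too, so the number for compound 3, 170 nM, reflects two changes at once and cannot be read as a clean guide.

The expected step is a 1.9-fold higher number from compound 2 to compound 4 (0.28 log units; within the scatter), a modest move towards a higher number, at the edge of the scatter. Compound 4 is estimated to give 90 nM in this assay, within a range from 30 nM to 300 nM.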

Compound 4, half-maximal inhibitory concentration: 8 nM
The estimate for compound 4 lay 11-fold (1.05 log units) above the measured number; measured number outside the range, below it.
By their numbers in this assay, from the lowest: compound 4; then compound 2; then compounds 3 and 1 (each within the scatter of the next).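

In this assay, the group on the carbonyl carbon can by itself shift the number: 2-cyclopropyl-4-hydroxy-5-methylpiperidin-1-yl in place of 2,2-dimethylpyrrolidin-1-yl gives a 5.9-fold lower number from compound 2 to compound 4 (0.77 log units; beyond the scatter). The earlier compounds shown here could not show this, as compound 1 and compound 3 each differ from compound 2 in more than one place, and this step also shows that a bigger group with a six-membered ring, a three-membered ring, a hydrogen-bond donor and a hydrogen-bond acceptor is compatible with a lower number here. Nothing measured in this set explains why the number falls.

The change alters the ring size and adds the cyclopropyl, hydroxy and methyl groups in a single step, so the compounds shown leave open which of these parts accounts for the lower number. From the compounds shown here alone, it also remains open whether the low number would hold with an amine or a carboxylic acid in place of the hydroxy group, or with a longer chain such as n-butyl in place of the cyclopropyl group.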